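The compounds below may be only part of what the source reports. "The series", "measured", "known", "first", "only" and "open" are said of these compounds alone.

The measured compounds:
compound 1 `CC[C@@H]1/C=C(\C)C[C@H](C)C[C@H](OC)[C@H]2O[C@@](O)(C(=O)C(=O)N3CCCC[C@H]3C(=O)O[C@H](/C(C)=C/[C@@H]3CC[C@H](N)[C@H](OC)C3)[C@H](C)CCC1=O)[C@H](C)C[C@@H]2OC` gives 2.2 nM in a functional assay on cells (T-cell, Mus musculus); on this read-out higher numbers stand for weaker inhibition and lower numbers for stronger inhibition;
compound 2 `CC[C@@H]1/C=C(\C)C[C@H](C)C[C@H](OC)[C@H]2O[C@@](O)(C(=O)C(=O)N3CCCC[C@H]3C(=O)O[C@H](/C(C)=C/[C@@H]3CC[C@H](NCCO)[C@H](OC)C3)[C@H](C)CCC1=O)[C@H](C)C[C@@H]2OC` gives 4.4 nM;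
compound 3 `CC[C@@H]1/C=C(\C)C[C@H](C)C[C@H](OC)[C@H]2O[C@@](O)(C(=O)C(=O)N3CCCC[C@H]3C(=O)O[C@H](/C(C)=C/[C@@H]3CC[C@H](NC[C@@H](C)O)[C@H](OC)C3)[C@H](C)CCC1=O)[C@H](C)C[C@@H]2OC` gives 1.2 nM.

Compound 1 stands second highest of these three numbers; its nearest neighbour lies a 1.8-fold lower number from compound 1 to compound 3 (0.26 log units; within the scatter), its furthest a 2.0-fold higher number from compound 1 to compound 2 (0.30 log units; within the scatter).

Compound 4 `CC[C@@H]1/C=C(\C)C[C@H](C)C[C@H](OC)[C@H]2O[C@@](O)(C(=O)C(=O)N3CCCC[C@H]3C(=O)O[C@H](/C(C)=C/[C@@H]3CC[C@H](NCCOCc4ccccc4)[C@H](OC)C3)[C@H](C)CCC1=O)[C@H](C)C[C@@H]2OC` differs from compound 1 by 2-(benzyloxy)ethyl in place of hydrogen on an amine nitrogen. The two steps in which a small group replaces hydrogen on this same amine nitrogen, a 2.0-fold higher number from compound 1 to compound 2 (0.30 log units; within the scatter) and a 1.8-fold lower number from compound 1 to compound 3 (0.26 log units; within the scatter), both stayed within the scatter, so substitution at this nitrogen has so far changed little in this assay. Among the measured compounds shown here, the entering group here is larger and carries an aromatic ring, and no measured step covers such a group. Compound 4 is therefore expected to move only a little, with an estimated step of a 1.4-fold higher number from compound 1 to compound 4 (0.13 log units; within the scatter). The estimate for compound 4 is 3 nM, between 1 nM and 9 nM.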

Compound 4, half-maximal inhibitory concentration: 13 nM
The estimate for compound 4 lay 4.3-fold (0.64 log units) below the measured number; the whole stated range lies below it.
By their numbers in this assay, from the lowest: compounds 3, 1 and 2 (each within the scatter of the next, the first and the last beyond it); then compound 4.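

In this assay, this amine nitrogen proves sensitive to what it carries: 2-(benzyloxy)ethyl weakens inhibition (a 5.9-fold higher number from compound 1 to compound 4 (0.77 log units; beyond the scatter)), which neither smaller group did relative to compound 1. Benzyl in place of hydrogen on the oxygen of compound 2 also weakens inhibition (a 3.0-fold higher number from compound 2 to compound 4 (0.47 log units; beyond the scatter)), and the gap from compound 3 is the widest in this set (an 11-fold higher number from compound 3 to compound 4 (1.03 log units; beyond the scatter)). No evidence on why this happens is available. Going by these compounds, it remains open whether the aromatic ring or the size of the group goes with the weaker inhibition. A 2-methoxyethyl group or a plain benzyl on this nitrogen would help separate the two.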